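The compounds below may be only part of what the source reports. "The series", "measured", "known", "first", "only" and "open" are said of these compounds alone.

Compound 1 `CO[C@]1(C)/C=C/C(=O)/C(CO)=C\C[C@](C)(CCC=C(C)C)/C=C/[C@H]1OC(=O)C=C(C)C`: 14400 nM
Compound 2 `CC(=O)O[C@@H]1/C=C/[C@@](C)(CCC=C(C)C)C/C=C(/CO)C(=O)/C=C/[C@@]1(C)O`: 8670 nM
Compound 3 `CC(C)=CCC[C@]1(C)/C=C/[C@@H](OC(=O)C(C)C)[C@](C)(O)/C=C/C(=O)/C(CO)=C\C1`: 10800 nM

These three numbers all come from a functional assay on A549 cells (Homo sapiens) for antiproliferative activity, read by MTT assay, with a stated time of 48 h (on this read-out higher numbers stand for weaker inhibition and lower numbers for stronger inhibition), and they sit close together. Compound 3, at 10800 nM on this read-out, lies within the scatter of both compound 1 and compound 2, so it holds no clearly separate place among them.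

The next compound, compound 4 `CC(C)=CCC[C@]1(C)/C=C/[C@@H](OC(=O)c2ccccc2)[C@](C)(O)/C=C/C(=O)/C(CO)=C\C1`, matches compound 3 except for one group: phenyl in place of isopropyl on a carbonyl carbon.

For the measured compounds named here, one measured step bears on this change. At that same kind of carbonyl carbon, isopropyl took the place of methyl, and the result was a 1.2-fold higher number from compound 2 to compound 3 (0.10 log units; within the scatter) in this assay, a small step that stays within the scatter. Compound 1 differs from compound 3 in more than one place, so it offers no clean comparison. Going by the values given here, no compound measured so far carries a ring on this carbonyl carbon, so the evidence reaches only part of the way and the range must stay wide. The expected step is a 1.1-fold lower number from compound 3 to compound 4 (0.03 log units; within the scatter) and it is not expected to go beyond the scatter, with no firm direction. For compound 4 the estimated value is 10000 nM, with an expected range from 4500 nM to 22000 nM.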

Compound 4, half-maximal inhibitory concentration: 15800 nM
For compound 4 the middle estimate is 1.6-fold (0.20 log units) below the measured one; low and high end bracket the measured number.
By their numbers in this assay, from the lowest: compounds 2, 3, 1 and 4 (each within the scatter of the next).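

For the compounds shown here, compound 4 is the first compound here with a ring on this carbonyl carbon, and in this assay phenyl in place of isopropyl gives a 1.5-fold higher number from compound 3 to compound 4 (0.17 log units; within the scatter), a step that stays within the scatter. Measured against the smaller methyl group, the same ring gives a 1.8-fold higher number from compound 2 to compound 4 (0.26 log units; within the scatter), which is also within the scatter, so methyl, isopropyl and phenyl on this carbonyl carbon cannot be told apart on this read-out, even though the new group brings a six-membered aromatic ring. Nothing available gives a measured reason for how small these steps are.

The groups shown on this carbonyl carbon contain only carbon and hydrogen, so it remains open whether a chain ending in an amine or a carboxylic acid would move the number beyond the scatter. Also open, on these data alone, is whether a longer chain, or a phenyl ring carrying a methoxy group or a fluorine, would give a clear step in either direction, and so whether this carbonyl carbon can change the number at all.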